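A few compounds are considered here, and "the series" means these few. Any claim that something is new, unique, unknown or untested is made for them only; others in the source may bear on it.

Going by the values given here, the three compounds measured so far share one core and differ only in the group on the amide-type nitrogen and on one aromatic carbon. Compound 1 `Cc1ccc(S(=O)(=O)N2C=CNC(=O)[C@H]2CC(=O)N[C@@H]2CCCc3cc(CN4CCCC4)ccc32)cc1` carries (pyrrolidin-1-yl)methyl on an aromatic carbon; in an in vitro ADME assay on microsomes from liver (Homo sapiens) for pharmacokinetics (on this read-out lower numbers stand for slow clearance and higher numbers for fast clearance), compound 1 gives < 50 mL.min-1.g-1, which is a limit of the assay rather than a number. Compound 2 `Cc1ccc(S(=O)(=O)N2C=CNC(=O)[C@H]2CC(=O)N[C@@H]2CCCc3ccccc32)cc1` has hydrogen in that place, and in this assay compound 2 gives 514 mL.min-1.g-1. Compound 3 `Cc1ccc(S(=O)(=O)N2C=CNC(=O)[C@H]2CC(=O)NC2CCCCC2)cc1` bears cyclohexyl on the amide-type nitrogen and gives 147 mL.min-1.g-1, the lowest of the two numbers, with compound 2 the nearest.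

The unmeasured compound 4 `Cc1ccc(S(=O)(=O)N2C=CNC(=O)[C@H]2CC(=O)N[C@H]2CCN(C)CC2(C)C)cc1` differs from compound 3 in one place: a group of 9 heavy atoms (8 carbon, 1 nitrogen; one six-membered non-aromatic ring with 1 hetero atom) in place of a group of 6 heavy atoms (6 carbon; one six-membered non-aromatic ring of carbon only), on an amide-type nitrogen. Among the compounds with values here, two measured steps bear on this. a 3.5-fold lower number from compound 2 to compound 3 (0.54 log units; beyond the scatter) shows that the group on the amide-type nitrogen can move the read-out by a modest amount. an at least 10-fold higher number from compound 1 to compound 2 (1.01 log units; beyond the scatter) shows that taking away a nitrogen-containing group produced a large rise, the starting point being (the limit of < 50 mL.min-1.g-1 in this assay, at which 1 of the 3 values shown sits). Because an at least 10-fold higher number from compound 1 to compound 2 (1.01 log units; beyond the scatter) was large, a step in the lowering direction is expected for compound 4, namely a 2.5-fold lower number from compound 3 to compound 4 (0.39 log units; beyond the scatter). Compound 4 is therefore estimated at 60 mL.min-1.g-1, with a range from 25 mL.min-1.g-1 to 150 mL.min-1.g-1, and it may well return only a limit.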

Compound 4, intrinsic clearance in microsomes: < 14 mL.min-1.g-1
Compound 4 gave a limit, no number (the forecaster's own chance of this, stated with the estimate: 40%); middle value at least 4.2-fold (0.63 log units) from the limit.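

In this assay, the group on the amide-type nitrogen now proves able to produce a large change and not only the modest one of a 3.5-fold lower number from compound 2 to compound 3 (0.54 log units; beyond the scatter): the entering group with its six-membered non-aromatic ring with 1 hetero atom gives an at least 10-fold lower number from compound 3 to compound 4 (1.02 log units; beyond the scatter). Set against the larger carbon-only group on the same nitrogen, the same entering group gives an at least 36-fold lower number from compound 2 to compound 4 (1.56 log units; beyond the scatter), so a large step at this position is seen from both measured neighbours. Both steps are bounds and not exact sizes, as compound 4 returned a limit of the assay: the limit of < 14 mL.min-1.g-1 in this assay, at which 1 of the 4 values shown sits.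

The compounds shown leave open how far the true read-out of compound 4 lies beyond that limit, and which feature of the entering group accounts for the step, since its nitrogen and its extra carbons enter together. A tetrahydropyranyl group on the amide-type nitrogen, with oxygen as its ring hetero atom, would bear on whether the ring nitrogen is what counts.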